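The source may report more compounds than this note shows. Statements on the series, on what has been measured and on what is new or still open speak of the compounds shown alone.

Measured in a functional assay on HeLa cells (Homo sapiens) for cytotoxicity, read by MTT assay, with a stated time of 48 h (a higher number here means a weaker inhibitor, a lower number a stronger inhibitor), each value a limit of the assay:
- Compound 1 `COc1ccc(/C=C/C(=O)/C=C/c2cc3ccccc3nc2Cl)c(OC)c1`: > 10000 nM
- Compound 2 `COc1cc(OC)c(/C=C/C(=O)/C=C/c2cc3ccccc3nc2Cl)c(OC)c1`: > 10000 nM
- Compound 3 `COc1ccc(/C=C/C(=O)/C=C/c2cc3ccccc3nc2Oc2ccccc2)cc1OC`: > 10000 nM

Compound 2 stands only at a limit, > 10000 nM, and has no number. The whole picture so far is the limit of > 10000 nM in this assay, at which 3 of the 3 values shown sit. Compound 4 `COc1cc(OC)c(/C=C/C(=O)/C=C/c2cc3ccccc3nc2Oc2ccc(Br)cc2)c(OC)c1` is reached from this point by a single exchange, 4-bromophenoxy in place of chloro on an aromatic carbon, next to the ring nitrogen: 4-bromophenoxy in place of chloro on an aromatic carbon.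

Within the data shown here, only one measured step exists, a step that the two limits leave unreadable from compound 1 to compound 2, and it is a different change, methoxy in place of hydrogen on an aromatic carbon. Its size cannot be read, so it gives no guide to size or direction here. Among the measured compounds shown here, no measured step covers the exchange of chloro for 4-bromophenoxy. With nothing to support a shift, no step beyond the scatter is expected in this assay, and a reported limit is the likeliest result, although a measurable number remains possible.

The estimated step is a number no higher from compound 2 to compound 4 (the limit leaves the size open). For compound 4 the estimate is 10000 nM, with an expected range from 2500 nM to 40000 nM.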

Compound 4, half-maximal inhibitory concentration: > 10000 nM
Compound 4: a limit, no number; the forecaster's own chance of this, stated with the estimate: 65%; the middle value sits exactly at the limit.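

Among these compounds, compound 2 and compound 4 both stand only at a limit in this assay, so the exchange of chloro for 4-bromophenoxy gives no step that can be read. The compounds shown leave open whether any change to the shared core yields a measurable number, for the picture stays as it was: the limit of > 10000 nM in this assay, at which 4 of the 4 values shown sit.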